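A few compounds are considered here, and "the series" means these few. Any claim that something is new, unique, unknown or untested is made for them only; others in the source may bear on it.

Notes on the series

Compound 1 `CCCCCC(=O)c1ccc(OCCCN2CCN(S(=O)(=O)c3ccc(C#N)cc3)CC2)cc1` is measured in an assay on isolated protein for binding affinity to histamine H2 receptor (Homo sapiens) (on this read-out lower numbers stand for stronger inhibition and higher numbers for weaker inhibition), at 12300 nM. Compound 2 `CCCCCC(=O)c1ccc(OCCCN2CCN(C(=O)C3CCC3)CC2)cc1` gives 10200 nM in this assay. The two numbers lie within the usual scatter of each other, so no order between compound 1 and compound 2 can be read from them; compound 1 simply carries the higher of the two figures as they stand. The step of a 1.2-fold lower number from compound 1 to compound 2 (0.08 log units; within the scatter) is the only measured one and it exchanges the sulfonyl group on the ring nitrogen for a carbonyl-bearing group.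

Compound 3 `CCCCCC(=O)c1ccc(OCCCN2CCN(C(=O)CSCC)CC2)cc1` is not yet measured. It differs from compound 1 in one place: ((ethylsulfanyl)methyl)carbonyl in place of (4-cyanophenyl)sulfonyl on an amine nitrogen in a ring. This change is of the same kind as the one measured, a carbonyl-bearing group entering on the ring nitrogen in place of the (4-cyanophenyl)sulfonyl group, and that step a 1.2-fold lower number from compound 1 to compound 2 (0.08 log units; within the scatter) stayed within the scatter. On that basis no step beyond the scatter is expected in this assay for compound 3, and the expected step is a 1.2-fold lower number from compound 1 to compound 3 (0.07 log units; within the scatter). The estimate for compound 3 in this assay is 10500 nM, with a range from 4000 nM to 26000 nM.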

Compound 3, inhibition constant: 22900 nM
Compound 3: middle estimate off by 2.2-fold (0.34 log units), on the low side, within the range that was stated.
By their numbers in this assay, from the lowest: compounds 2, 1 and 3 (each within the scatter of the next, the first and the last beyond it).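

In this assay, among these compounds, the acyl groups on the ring nitrogen are now separated for the first time: with the carbonyl held in place, (ethylsulfanyl)methyl in place of cyclobutyl on the carbonyl carbon gives a 2.2-fold higher number from compound 2 to compound 3 (0.35 log units; beyond the scatter), a modest step but one that shows this position is not wholly indifferent to the group carried there. The exchange of (4-cyanophenyl)sulfonyl for ((ethylsulfanyl)methyl)carbonyl gives a 1.9-fold higher number from compound 1 to compound 3 (0.27 log units; within the scatter), so the loss of the aromatic ring and the sulfonyl group, and the smaller group that enters, do not separate compound 1 from compound 3 in this assay, just as the exchange for cyclobutylcarbonyl did not separate compound 1 from compound 2. No measurement on hand accounts for the difference between the cyclobutyl and (ethylsulfanyl)methyl groups.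

The compounds shown leave open whether the step on the carbonyl carbon follows the sulfur in the chain or the open chain itself, which an all-carbon chain of the same length on that carbon would help to settle. From the compounds shown here alone, it also remains open whether an amine or a carboxylic acid on that chain would give a step of any larger size, in either direction, than the ones seen so far.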